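Working notes on cytotoxicity in a small diaryl ether series

The compounds below may be only part of what the source reports. "The series", "measured", "known", "first", "only" and "open" are said of these compounds alone.

Measured so far:
compound 1 `Cc1cc(/C=C/C#N)cc(C)c1Oc1nc(Nc2ccc(CN3CCN(S(N)(=O)=O)CC3)cc2)nc2ccsc12` — 145000 nM
compound 2 `Cc1cc(/C=C/C#N)cc(C)c1Oc1nc(Nc2ccc(N3CCNCC3)cc2)nc2sccc12` — 4740 nM

In an ADME assay on MT4 cells (Homo sapiens) for cytotoxicity, read by MTT assay, with a stated time of 5 days (on this read-out higher numbers stand for lower toxicity in this test and lower numbers for higher toxicity in this test), compound 1 gives 145000 nM, the highest of the two numbers recorded. The nearest is compound 2, which gives 4740 nM, a gap that lies beyond the scatter. For the measured compounds named here, compound 2 differs from compound 1 in more than one place, so no single step is drawn between them; the two values show only that compound 1 is the less toxic of the pair in this test.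

Compound 3 `Cc1cc(/C=C/C#N)cc(C)c1Oc1nc(Nc2ccc(N3CCN(S(C)(=O)=O)CC3)cc2)nc2ccsc12` is not yet measured. It differs from compound 1 as follows: 4-(methylsulfonyl)piperazin-1-yl in place of (4-sulfamoylpiperazin-1-yl)methyl on an aromatic carbon. Going by the values given here, no measured step covers this change, so the expectation rests on the two values above. Compound 2, which also carries a piperazine directly on the ring, gives 4740 nM, so a lower number than compound 1 is expected for compound 3, though the sulfonyl group is kept. For compound 3 in this assay the expected value is 40000 nM, within 8000 nM to 150000 nM. The expected step of a 3.6-fold lower number from compound 1 to compound 3 (0.56 log units; beyond the scatter) is a moderate fall, likely beyond the scatter.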

Compound 3, half-maximal cytotoxic concentration: 11500 nM
Beside the measured number, compound 3's estimate is 3.5-fold (0.54 log units) above it, within the range that was stated.
By their numbers in this assay, from the lowest: compound 2; then compound 3; then compound 1.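

In this assay, for the compounds shown here, the change on this aromatic carbon, para to a large group, gives the first readable step: a 13-fold lower number from compound 1 to compound 3 (1.10 log units; beyond the scatter). This position is therefore not silent for cytotoxicity, and 4-(methylsulfonyl)piperazin-1-yl goes with the higher toxicity in this test, although the sulfonyl group is kept and the piperazine ring stays in the molecule. No measurement bears on the reason for this step.

The step joins two differences in one exchange, the methyl link of the leaving group and the end of the piperazine, where sulfamoyl gives way to methylsulfonyl, and the compounds shown do not separate them. A 4-sulfamoylpiperazin-1-yl group or a (4-(methylsulfonyl)piperazin-1-yl)methyl group on the same carbon would show which of the two carries the step.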